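The source may hold more compounds than are shown below. What is called first, only, known or untested is meant among the compounds shown, and "the series" means these compounds.

Values measured in a functional assay on PC-3 cells (Homo sapiens) for inhibition, read by sulforhodamine B assay, with a stated time of 48 h (on this read-out higher numbers stand for weaker inhibition of growth and lower numbers for stronger inhibition of growth), are as follows.
- compound 1 `CCOC(=O)C1=C(C)NC(=S)NC1c1ccc(O)cc1` gives 47.6 ug/mL
- compound 2 `CCOC(=O)C1=C(C)NC(=S)NC1c1ccc(O)c(O)c1` gives 25 ug/mL

Compound 1 has a single measured neighbour, and the two values lie within the scatter of each other, so neither can be ranked. Among the compounds with values here, the only measured step is a 1.9-fold lower number from compound 1 to compound 2 (0.28 log units; within the scatter) and it is the sole guide available.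

Still unmeasured is compound 3 `CCCc1ccc(C2NC(=S)NC(C)=C2C(=O)OCC)cc1` with the change propyl in place of hydroxy on an aromatic carbon in which propyl takes the place of hydroxy on an aromatic carbon, para to a large group. Within the data shown here, the measured step bears on this only loosely: it adds a hydroxy rather than removing one, and no measured compound carries propyl. The data therefore give no direction for the change.

On the small size of a 1.9-fold lower number from compound 1 to compound 2 (0.28 log units; within the scatter) no step beyond the scatter is expected in this assay and the range is kept wide on both sides. The expected step is a 1.2-fold lower number from compound 1 to compound 3 (0.08 log units; within the scatter) as an estimate only. Compound 3 is expected at 40 ug/mL with an estimated range of 15 ug/mL to 100 ug/mL for now.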

Compound 3, concentration for 50% growth inhibition: 42.4 ug/mL
Compound 3: the middle estimate sits 1.1-fold (0.03 log units) below what was measured, and the stated range covers the measured number.
By their numbers in this assay, from the lowest: compounds 2, 3 and 1 (each within the scatter of the next).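

In this assay the change from hydroxy to propyl on an aromatic carbon, para to a large group, gives a 1.1-fold lower number from compound 1 to compound 3 (0.05 log units; within the scatter) and so does not separate the two groups at this position. Within the data shown here, this is the first view of the hydroxy of compound 1 being replaced rather than joined by a second one, and the exchange is not a small one on paper: the entering propyl has 3 heavy atoms, 0 hydrogen-bond donors and 0 hydrogen-bond acceptors, against 1 heavy atom, 1 hydrogen-bond donor and 1 hydrogen-bond acceptor for the leaving hydroxy. Nothing available on the compounds explains why the read-out stays within the scatter across this exchange.

Going by these compounds, whether an amine, a carboxylic acid or a longer chain at this position would give a step beyond the scatter remains open. On these data alone, with compounds 1, 2 and 3 all lying within the scatter of their neighbours, it also remains open whether any change at this place can move the number in this assay at all.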